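Swapping hydroxy for phenyl on a saturated side chain

A few compounds are considered here, and "the series" means these few. Any claim that something is new, unique, unknown or untested is made for them only; others in the source may bear on it.

Compound 1 `C=CCc1cc(O)c(O)c(CN2CCC(C)CC2)c1`: 41.7%
Compound 2 `C=CCc1cc(O)c(O)c(CN2CCC(CCO)CC2)c1`: 21.4%
Compound 3 `C=CCc1cc(O)c(O)c(CN2CCC(CO)CC2)c1`: 26.2%

All three compounds were tested in a functional assay on MCF7 cells (Homo sapiens) for inhibition, read by MTT assay, with a stated time of 72 h, tested at 30 uM; on this read-out higher numbers stand for more inhibition of growth at the one concentration tested and lower numbers for less inhibition of growth. Compound 3 cannot be told apart from compound 2, the gap being a number 4.8 percentage points higher from compound 2 to compound 3 (within the scatter), and both stand under compound 1.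

The next compound is compound 4 `C=CCc1cc(O)c(O)c(CN2CCC(Cc3ccccc3)CC2)c1`, which differs from compound 3 as follows: phenyl in place of hydroxy on a saturated chain carbon bound to a saturated ring carbon. Cut one bond further out, hydroxymethyl gives way to benzyl.

Within the data shown here, no measured step shows phenyl at this place, so the evidence is indirect. Among the measured compounds shown here, two steps bear on it, a number 15.5 percentage points lower from compound 1 to compound 3 (beyond the scatter) and a number 20.3 percentage points lower from compound 1 to compound 2 (beyond the scatter), and each ends on a compound carrying a hydroxy. Compound 4 carries none, so a rise of similar size, beyond the scatter, is expected. The estimated change is a number 18.8 percentage points higher from compound 3 to compound 4 (beyond the scatter). For compound 4 the expected value is 45%, with an estimated range from 25% to 70%.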

Compound 4, percent growth inhibition at one concentration: 70.9%
Estimate against measurement, compound 4: 25.9 percentage points below; the whole stated range lies below it.
By their numbers in this assay, from the lowest: compounds 2 and 3 (each within the scatter of the next); then compound 1; then compound 4.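

Until now, both steps away from compound 1 at this place, on a saturated chain carbon bound to a saturated ring carbon, had lowered the number, but in this assay phenyl in place of hydrogen gives a number 29.2 percentage points higher from compound 1 to compound 4 (beyond the scatter) and shows that the place can also carry a gain. Compound 4 thus does more than return to the level of compound 1, which also carries no hydroxy. Against the two hydroxy compounds the change is large, with a number 44.7 percentage points higher from compound 3 to compound 4 (beyond the scatter) for phenyl in place of hydroxy and a number 49.5 percentage points higher from compound 2 to compound 4 (beyond the scatter) for phenyl in place of hydroxymethyl.

As far as these compounds go, whether the aromatic ring itself matters or only the added carbon stays open, as does what a cyclohexyl group in place of the phenyl or an amine on the same chain would give. Nothing measured here explains the rise.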